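The source may hold more compounds than are shown below. What is called first, only, known or untested is meant among the compounds shown, and "the series" means these compounds.

Measured in an ADME assay on H9 cells (Homo sapiens) for cytotoxicity, read by XTT assay, with a stated time of 6 days; on this read-out lower numbers stand for higher toxicity in this test and higher numbers for lower toxicity in this test:
- compound 1 `Cc1cc(Br)cc(C)c1Oc1cc(Nc2ccc(C#N)cc2)c(N)cc1N`: 38400 nM
- compound 2 `Cc1cc(C)c(Oc2cc(Nc3ccc(C#N)cc3)c(N)cc2[N+](=O)[O-])c(C)c1`: 32200 nM
- compound 3 `Cc1cc(C#N)cc(C)c1Oc1ccc([N+](=O)[O-])c(Nc2ccc(C#N)cc2)c1`: > 65100 nM

Not yet measured: compound 4 `Cc1cc(C#N)cc(C)c1Oc1cc(Nc2ccc(C#N)cc2)c(N)cc1N`.

Among the compounds with values here, only two of these readings are numbers. Compound 1, at 38400 nM, and compound 2, at 32200 nM, lie within the usual scatter of each other, so no order can be drawn between them. Compound 3 gives only a limit, > 65100 nM, and not a number.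

Compound 4 differs from compound 1 in one place: cyano in place of bromo on an aromatic carbon, meta to two methyl groups and para to a large group. The counted difference is cyano in place of bromo on an aromatic carbon.

Within the data shown here, no step between measured compounds that differ in one place is available in this assay, so the size of this change has no direct precedent. The expectation therefore stays close to compound 1 at 38400 nM, with no shift beyond the scatter in either direction. The expected change is a 1.1-fold lower number from compound 1 to compound 4 (0.04 log units; within the scatter). A reading of compound 4 as a limit also remains possible.

For compound 4 the estimated value in this assay is 35000 nM, with an expected range of 14000 nM to 68000 nM.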

Compound 4, half-maximal cytotoxic concentration: 51000 nM
Beside the measured number, compound 4's estimate is 1.5-fold (0.16 log units) below it; the measured number falls inside the stated range.
By their numbers in this assay, from the lowest: compounds 2, 1 and 4 (each within the scatter of the next). At a limit, above all of these: compound 3.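

In this assay, the aromatic carbon meta to two methyl groups and para to a large group now has its first one-place step: cyano in place of bromo gives a 1.3-fold higher number from compound 1 to compound 4 (0.12 log units; within the scatter). Cyano brings two heavy atoms and a hydrogen-bond acceptor where bromo brought one heavy atom and none, yet this test does not separate compound 1 from compound 4, so the counted differences in this swap come with no change that can be told from scatter. No measurement shown bears on the cause of this result.

As far as these compounds go, one step with two groups says little about how much this position can tolerate, and it remains open whether an amine, a carboxylic acid or a longer chain in place of cyano or bromo would move the number beyond the scatter. From the compounds shown here alone, it also remains open whether the same swap would read the same way on a core that differs elsewhere, for example with a nitro group in place of one of the amino groups of compound 4.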